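Hydroxy to ethoxy on compound 3

The compounds below may be only part of what the source reports. "The series", "measured", "known", "first", "only" and "open" are said of these compounds alone.

Compound 1 `Cc1coc(-c2ccc3c(c2O)CCCC3)c1C(=O)O` gives 57 uM
Compound 2 `Cc1coc(-c2ccc3c(c2O)CCCC3(C)C)c1C(=O)O` gives 3.3 uM
Compound 3 `Cc1coc(-c2ccc3c(c2O)CCCC3(C)C)c1CO` gives 24.5 uM

In a functional assay on A549 cells (Homo sapiens) for cytotoxicity, read by sulforhodamine B assay, with a stated time of 3 days (a higher number here means that more compound is needed for the effect, a lower number that less compound is needed), compound 3 holds the middle of the three numbers, with compound 1 higher and compound 2 lower. Compound 4 `CCOc1c(-c2occ(C)c2CO)ccc2c1CCCC2(C)C` differs from it by ethyl in place of hydrogen on an oxygen on an aromatic ring with ethyl in place of hydrogen on an oxygen on an aromatic ring, so hydroxy becomes ethoxy. Among the compounds with values here, the only measured single change, a 7.4-fold higher number from compound 2 to compound 3 (0.87 log units; beyond the scatter) with hydroxymethyl in place of carboxy, leaves this hydroxy untouched. It shows that one change can shift the number but gives no direction here. No step beyond the scatter is therefore expected, and the estimated step is a 1.2-fold higher number from compound 3 to compound 4 (0.09 log units; within the scatter) with a wide margin. Compound 4 is expected to give 30 uM with a range of 9 uM to 80 uM in this estimate.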

Compound 4, concentration for half-maximal effect: 22.9 uM
For compound 4 the middle estimate is 1.3-fold (0.12 log units) above the measured one; the measured number falls inside the stated range.
By their numbers in this assay, from the lowest: compound 2; then compounds 4 and 3 (each within the scatter of the next); then compound 1.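

Within the data shown here, compounds 1 to 3 all keep the hydroxy, so this is the first test of this oxygen: ethyl in place of hydrogen gives a 1.1-fold lower number from compound 3 to compound 4 (0.03 log units; within the scatter) in this assay. The hydrogen on this oxygen can therefore be replaced by ethyl with no step beyond the scatter, at least in a compound carrying hydroxymethyl. No supporting measurement bears on this result.

Going by these compounds, whether ethoxy would do the same in compound 2, which carries carboxy, stays open. So does the outcome for a longer chain, such as butyl, on this oxygen, or an amine in place of the hydroxy.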